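Adding an aminophenyl group to a weak growth inhibitor

A few compounds are considered here, and "the series" means these few. Any claim that something is new, unique, unknown or untested is made for them only; others in the source may bear on it.

Among the compounds with values here, in a functional assay on HCT-116 cells (Homo sapiens) for cytotoxicity, read by MTT assay, with a stated time of 48 h (on this read-out higher numbers stand for weaker inhibition of growth and lower numbers for stronger inhibition of growth), compound 1 `Cn1c(C(F)(F)F)nc2cc(Cl)c(Cl)cc21` gives 56000 nM, the highest number of the three compounds measured so far and therefore the weakest inhibition of growth. Compound 2 `FC(F)(F)c1ccc(Cn2c(C(F)(F)F)nc3cc(Cl)c(Cl)cc32)cc1` gives 19000 nM, and compound 3 `O=[N+]([O-])c1ccccc1Cn1c(C(F)(F)F)nc2cc(Cl)c(Cl)cc21` gives 5900 nM. Both share the core of compound 1 and carry a substituted aromatic ring on the saturated chain carbon bound to an aromatic nitrogen.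

Compound 4 `Nc1cccc(Cn2c(C(F)(F)F)nc3cc(Cl)c(Cl)cc32)c1` has yet to be measured. Its change from compound 1 is 3-aminophenyl in place of hydrogen on a saturated chain carbon bound to an aromatic nitrogen. Within the data shown here, no two measured compounds differ in only one place, so the size of this step can be judged only loosely. The guides are compound 2 at 19000 nM and compound 3 at 5900 nM, which both suggest a lower number. The expected change is a 4.0-fold lower number from compound 1 to compound 4 (0.60 log units; beyond the scatter), a step toward stronger inhibition and beyond the scatter. For compound 4 the estimated value in this assay is 14000 nM, within an expected range of 4500 nM to 45000 nM.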

Compound 4, concentration for 50% growth inhibition: 22600 nM
The estimate for compound 4 lay 1.6-fold (0.21 log units) below the measured number, within the range that was stated.
By their numbers in this assay, from the lowest: compound 3; then compounds 2 and 4 (each within the scatter of the next); then compound 1.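

In this assay, within the data shown here, this is the first step measured at this position: a 2.5-fold lower number from compound 1 to compound 4 (0.39 log units; beyond the scatter), a modest move toward stronger inhibition of growth that lies beyond the scatter. It shows directly that replacing hydrogen with 3-aminophenyl on the saturated chain carbon bound to an aromatic nitrogen, a change that adds 7 heavy atoms, keeps growth inhibition and somewhat strengthens it. Nothing measured here accounts for the size or direction of this step.

The compounds shown leave open how much of the step comes from the aromatic ring itself and how much from its amino group, a question that an unsubstituted phenyl ring at the same place would address. They also leave open how a carboxylic acid in place of the amino group would change the number.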